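The compounds below may be only part of what the source reports. "The series", "measured", "known", "first", "only" and "open" are said of these compounds alone.

Of the compounds shown here, two on the shared core have been read so far in a toxicity assay on MT4 cells (Homo sapiens) for cytotoxicity, read by MTT assay; a lower number here means that less compound is tolerated, a higher number that more compound is tolerated. Among the compounds with values here, compound 1 (`Cc1ccccc1-c1cc(C)c(Oc2cc(N)nc(Nc3ccc(C#N)cc3)n2)c(C)c1`) gives 25600 nM and compound 2 (`Cc1cc(-c2cccc(C#N)c2)cc(C)c1Oc1cc(N)nc(Nc2ccc(C#N)cc2)n1`) gives 20200 nM, so compound 2 stands within the scatter of the only other number available. Compound 3 (`Cc1cc(-c2cccc(C#N)c2)ccc1Oc1cc(N)nc(Nc2ccc(C#N)cc2)n1`) keeps the 3-cyanophenyl group of compound 2 and carries hydrogen in place of methyl on an aromatic carbon, ortho to a large group and meta to the 3-cyanophenyl group: hydrogen in place of methyl on an aromatic carbon. Within the data shown here, no measured step removes or adds a methyl at this place, so there is no direct precedent. Among the measured compounds shown here, the one measured step bears on it only indirectly: 3-cyanophenyl in place of 2-methylphenyl gives a 1.3-fold lower number from compound 1 to compound 2 (0.10 log units; within the scatter). That exchange involves a much larger group than a single methyl, yet its size stays within the scatter, so no shift beyond the scatter is expected in this assay. The expected step is a 1.1-fold lower number from compound 2 to compound 3 (0.05 log units; within the scatter). For compound 3 the estimated value is 18000 nM, with an expected range of 7000 nM to 45000 nM.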

Compound 3, half-maximal cytotoxic concentration: 27400 nM
Beside the measured number, compound 3's estimate is 1.5-fold (0.18 log units) below it; measured number inside the range.
By their numbers in this assay, from the lowest: compounds 2, 1 and 3 (each within the scatter of the next).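

Within the data shown here, at this place, on an aromatic carbon ortho to a large group and meta to a 3-cyanophenyl group, hydrogen in place of methyl gives a 1.4-fold higher number from compound 2 to compound 3 (0.13 log units; within the scatter) in this assay and so provides the first direct reading for this position. The methyl group is therefore not needed to keep the number in this assay within the scatter of compound 2, and this single-carbon change joins the larger exchange of a 1.3-fold lower number from compound 1 to compound 2 (0.10 log units; within the scatter) in staying within the scatter, although the two steps lie at different places and only these three compounds support the comparison. No measured information is available to explain why this position tolerates the change in this way.

The compounds shown carry only methyl or hydrogen at this place, so it remains open whether a chlorine atom, a methoxy group or an amine there would move the number beyond the scatter. On these data alone, it is also open whether hydrogen in place of methyl would give a similar step with 2-methylphenyl in place of the 3-cyanophenyl group.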